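Swapping the aryl group on the amine nitrogen again

The source may report more compounds than this note shows. Statements on the series, on what has been measured and on what is new or still open speak of the compounds shown alone.

Measured so far:
- compound 1 `Cc1ccc(S(=O)(=O)/N=C(/CCNC2=CC(=O)c3ccccc3C2=O)Nc2ccc(F)cc2)cc1`: 12200 nM
- compound 2 `Cc1ccc(S(=O)(=O)/N=C(/CCNC2=CC(=O)c3ccccc3C2=O)Nc2ccccc2I)cc1`: 11700 nM

Both compounds share one core and differ only in the substituted phenyl group attached to an amine nitrogen. In a functional assay on DU-145 cells (Homo sapiens) for cytotoxicity, read by MTT assay, with a stated time of 48 h (a higher number here means a weaker inhibitor, a lower number a stronger inhibitor), compound 1 gives 12200 nM, and compound 2 gives 11700 nM. The step of a 1.0-fold lower number from compound 1 to compound 2 (0.02 log units; within the scatter) lies within the scatter, so compound 2 stands at essentially the same level as compound 1; neither can be called stronger or weaker.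

Compound 3 `Cc1ccc(S(=O)(=O)/N=C(/CCNC2=CC(=O)c3ccccc3C2=O)Nc2cc(F)c(F)c(F)c2)cc1` is not yet measured. It differs from compound 2 in one place: 3,4,5-trifluorophenyl in place of 2-iodophenyl on an amine nitrogen.

Among the measured compounds shown here, the only measured step that bears on this change is a 1.0-fold lower number from compound 1 to compound 2 (0.02 log units; within the scatter), which also exchanged one substituted phenyl for another on the same amine nitrogen and produced no movement beyond the scatter. With just that one precedent, the expectation for a third substituted phenyl in the same place is again no step beyond the scatter, that is a 1.0-fold lower number from compound 2 to compound 3 (0.01 log units; within the scatter). Compound 3 is therefore estimated at 11500 nM in this assay, with a range from 5000 nM to 26000 nM.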

Compound 3, half-maximal inhibitory concentration: 12600 nM
Estimate against measurement, compound 3: 1.1-fold (0.04 log units) below, and the stated range covers the measured number.
By their numbers in this assay, from the lowest: compounds 2, 1 and 3 (each within the scatter of the next).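

In this assay, a third substituted phenyl on this amine nitrogen again brings no movement beyond the scatter: the change from 2-iodophenyl to 3,4,5-trifluorophenyl gives a 1.1-fold higher number from compound 2 to compound 3 (0.03 log units; within the scatter), and the change from 4-fluorophenyl to the same group gives a 1.0-fold higher number from compound 1 to compound 3 (0.01 log units; within the scatter). Where the earlier compounds offered a single exchange, there are now three groups to compare, and the three compounds stand within the scatter of one another whether the ring carries one fluorine, one iodine or three fluorines, so for these three groups the choice of halogen and their number on the phenyl ring makes no readable difference. No measurement is available that would say why the numbers stay level.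

On these data alone, all three groups are phenyl rings bearing fluorine or iodine, so it remains open whether an unsubstituted phenyl, a methoxyphenyl or a non-aromatic group such as cyclohexyl on the same nitrogen would stay at this level. As far as these compounds go, it also remains open whether any change to the shared core would move the number when the aryl group does not.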